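Cytotoxicity notes: amide swap on the shared core

A few compounds are considered here, and "the series" means these few. Any claim that something is new, unique, unknown or untested is made for them only; others in the source may bear on it.

Measured so far:
- compound 1, `COc1cccc(OC)c1C(=O)Nc1c[nH]nc1C(=O)N[C@H]1CC[C@H](O)CC1`: 34000 nM
- compound 2, `CO[C@H]1CC[C@H](NC(=O)c2n[nH]cc2NC(=O)c2ccc(F)cc2F)CC1`: 11000 nM

In an ADME assay on MRC5 cells (Homo sapiens) for inhibition, with a stated time of 72 h (a lower number here means that less compound is needed, a higher number that more compound is needed for the effect), compound 1 gives 34000 nM, the higher of the two numbers recorded. Compound 2 gives 11000 nM in this assay, and the gap between these two is stated to lie beyond the usual scatter. Compounds 1 and 2 differ in more than one place, so their pair is not read as a single step.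

The unmeasured compound 3, `COc1cccc(OC)c1C(=O)Nc1c[nH]nc1C(=O)NCc1ncccc1C`, follows from compound 1 by one change: (3-methylpyridin-2-yl)methyl in place of 4-hydroxycyclohexyl on an amide-type nitrogen.

Among the measured compounds shown here, no measured step covers this change, so the direction in this assay is unknown. Both measured numbers are high, and the series gives no sign that one change at this position moves the number far. The step from compound 1 to compound 3 is expected to be modest: a 1.5-fold lower number from compound 1 to compound 3 (0.19 log units; within the scatter), towards a lower number. For compound 3 the expected result in this assay is 22000 nM, with a range from 6000 nM to 80000 nM. A result reported only as a limit is also considered likely.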

Compound 3, half-maximal effective concentration: > 50000 nM
Compound 3: a limit, no number; the forecaster's own chance of this, stated with the estimate: 30%; at least 2.2-fold (0.35 log units) between middle value and limit.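

Among the compounds shown here, this is the first measured change at this amide-type nitrogen, and the value of compound 3 in this assay is a limit of the assay and not a number. The step gives only a floor, an at least 1.4-fold higher number from compound 1 to compound 3 (0.16 log units; that floor lies within the scatter), so the direction is not secured beyond the scatter, though the change does not bring the number down. At this position, (3-methylpyridin-2-yl)methyl in place of 4-hydroxycyclohexyl exchanges a six-membered non-aromatic ring of carbon only for a six-membered aromatic ring with 1 hetero atom, and no lower number follows, whereas the earlier pair of compound 1 and compound 2 differed in more than one place and could not speak to this position alone.

As far as these compounds go, how far compound 3 lies past the limit, and so the true size of the step, stays open: the limit of > 50000 nM in this assay, at which 1 of the 3 values shown sits. Nor do the compounds shown separate the parts of the change, the ring nitrogen, the methyl and the loss of the hydroxyl, and a plain benzyl group or a longer chain carrying an amine on the same nitrogen lies outside them.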